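This account rests on a few compounds, and the source may have more. Where it says the series, first, only, none or still open, it means among the compounds named here.

Measured so far in an assay on HEK293 cells for inhibition of Voltage-dependent T-type calcium channel subunit alpha-1G (Homo sapiens), read by fluorescence, tested at 10 uM; on this read-out lower numbers stand for less inhibition and higher numbers for more inhibition at the one concentration tested (going by the name of the read-out):

Compound 1 `CCCc1nc(-c2ccccc2)c(CNCCN2CCN(C(c3ccccc3)c3ccccc3)CC2)o1` gives 71.9%
Compound 2 `CCCc1nc(-c2ccccc2)c(CNCCN2CCN(c3ccccn3)CC2)o1` gives 48.1%

Within the data shown here, compound 2 stands at the lowest of these two numbers; the only other compound, compound 1, lies a good way higher, by a gap that is beyond the usual scatter of this kind of measurement. Compound 3 `CCCc1nc(-c2ccccc2)c(CNCCN2CCN(c3cccc(C)c3)CC2)o1` has not yet been measured. It differs from compound 2 in a single place: 3-methylphenyl in place of pyridin-2-yl on an amine nitrogen in a ring. Among the measured compounds shown here, no two measured compounds differ in only one place, so there is no directly comparable step to lean on. What the two numbers do show is that compound 1, carrying a different group at the same ring nitrogen, gives the higher reading, so a change at this spot can move the result by a sizeable amount. For compound 3 a modest rise is expected, a number 7.9 percentage points higher from compound 2 to compound 3 (within the scatter), smaller than the gap to compound 1 and not far outside the scatter. The estimate for compound 3 is therefore 56%, within a range of 32% to 78%.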

Compound 3, a percentage reported as inhibition, at one concentration (the size of the read-out at that concentration, not a potency): 43.1%
Compound 3: middle estimate off by 12.9 percentage points, on the high side, and the stated range covers the measured number.
By their numbers in this assay, from the lowest: compounds 3 and 2 (each within the scatter of the next); then compound 1.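

In this assay, among these compounds, this is the first step that can be read directly at this ring nitrogen: 3-methylphenyl in place of pyridin-2-yl gives a number 5 percentage points lower from compound 2 to compound 3 (within the scatter). The entering ring is carbon only and has no hydrogen-bond acceptor, whereas the leaving ring has one, yet the two readings cannot be told apart. No measurement at hand explains this result.

As far as these compounds go, the ring nitrogen and the methyl group are exchanged together in this step, so what each does alone remains open, and plain phenyl would help to separate them. Also open, from the compounds shown here alone, is how a quite different group at this spot would read, such as a carboxylic acid or an amine-bearing chain.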